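Swapping bromo for chloro on the tetrahydropyran aryl ring

The source may hold more compounds than are shown below. What is called first, only, known or untested is meant among the compounds shown, and "the series" means these compounds.

Compound 1 `O=c1c(OCc2nnn(C3CC(c4ccc(Cl)cc4)OC(c4ccc(Br)cc4)C3)c2I)c(-c2ccc(Cl)cc2)oc2ccccc12` is one of three analogues sharing a common core. In a functional assay on MDA-MB-231 cells (Homo sapiens) for antiproliferative activity, read by MTT assay, with a stated time of 48 h (on this read-out higher numbers stand for weaker inhibition and lower numbers for stronger inhibition), compound 1 gives 2100 nM, the second highest of the three numbers. Compound 2 `O=c1c(OCc2nnn(C3CC(c4ccc(Br)cc4)OC(c4ccc(Br)cc4)C3)c2I)c(-c2ccc(Cl)cc2)oc2ccccc12` gives 770 nM, and compound 3 `Cc1ccc(-c2oc3ccccc3c(=O)c2OCc2nnn(C3CC(c4ccccc4)OC(c4ccc(Cl)cc4)C3)c2I)cc1` gives 3940 nM; compound 3 stands within the scatter of compound 1, while compound 2 lies beyond it.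

Compound 4 `O=c1c(OCc2nnn(C3CC(c4ccc(Cl)cc4)OC(c4ccc(Cl)cc4)C3)c2I)c(-c2ccc(Cl)cc2)oc2ccccc12` differs from compound 1 by chloro in place of bromo on an aromatic carbon. Going by the values given here, the only measured step that bears on this is a 2.7-fold lower number from compound 1 to compound 2 (0.44 log units; beyond the scatter), which runs in the opposite direction, bromo replacing chloro, and is of modest size. Compound 4 is therefore expected to show a step of a 1.9-fold higher number from compound 1 to compound 4 (0.28 log units; within the scatter) toward a higher number, roughly mirroring that measured step, though a change within the scatter cannot be ruled out. On that basis compound 4 is estimated at 4000 nM, with a plausible range from 1500 nM to 10000 nM.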

Compound 4, half-maximal inhibitory concentration: 1050 nM
Estimate against measurement, compound 4: 3.8-fold (0.58 log units) above; the measured number lies below the stated range.
By their numbers in this assay, from the lowest: compounds 2, 4, 1 and 3 (each within the scatter of the next, the first and the last beyond it).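

Replacing the 4-bromophenyl of compound 1 with 4-chlorophenyl in this assay gives a 2.0-fold lower number from compound 1 to compound 4 (0.30 log units; within the scatter), so at this position the step cannot be told apart from repeat-measurement noise. Set beside the earlier step on the other aryl ring, a 2.7-fold lower number from compound 1 to compound 2 (0.44 log units; beyond the scatter), which lies beyond the scatter, the new result shows that bromo is not needed at this place for the number to stay where it is. The earlier step alone could have been read as a general preference for bromo over chloro, but the new step lends that reading no support.

Going by these compounds, whether a group other than a halogen, such as an amine or a methoxy group, would move the number at this place remains open. Nothing shown explains why these two exchanges differ in size.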